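The compounds below may be only part of what the source reports. "The series", "measured", "known", "first", "only" and "open" are said of these compounds alone.

Measured compounds:
compound 1 `COc1cc(C)nc2n/c(=N/C(=O)c3c(-c4ccc(Cl)cc4Cl)noc3C)sn12` — 80.5%
compound 2 `COc1cc(SC)nc(NC(=S)NC(=O)c2c(-c3ccc(Cl)cc3Cl)noc2C)n1` — 40.9%
compound 3 `CSc1cc(C)nc(NC(=S)NC(=O)c2c(-c3ccc(Cl)cc3Cl)noc2C)n1` — 47.1%

In a functional assay on the whole organism (strain L.) for inhibition, with Echinochloa crus-galli as the target, with a stated time of 72 h, tested at 100 mg/L (a lower number here means less inhibition of growth, a higher number more inhibition of growth at the concentration tested), compound 1 stands highest of the three; compound 3 and compound 2 lie well below it. Between compound 3 and compound 2 the change is methoxy in place of methyl on an aromatic carbon, and the step is a number 6.2 percentage points lower from compound 3 to compound 2 (within the scatter). Compound 4 `COc1cc(OC)n2s/c(=N\C(=O)c3c(-c4ccc(Cl)cc4Cl)noc3C)nc2n1` is not yet measured; it differs from compound 1 by methoxy in place of methyl on an aromatic carbon. This is the same kind of change as from compound 3 to compound 2, but the surroundings differ: in compound 4 the carbon is part of a fused or bridged system of two rings, meta to a fused ring and meta to a methoxy group, whereas in compound 2 it is meta to a large group and meta to a methylsulfanyl group. The difference between the core of compound 1 and the core of compound 3 is not broken down here. For compound 4 a step like a number 5.5 percentage points lower from compound 1 to compound 4 (within the scatter) is expected, resting on compound 3 to compound 2 giving a number 6.2 percentage points lower from compound 3 to compound 2 (within the scatter), which stayed within the scatter. Compound 4 is therefore estimated at 75%, with a range from 60% to 88%.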

Compound 4, percent growth inhibition at one concentration: 85.6%
Compound 4: middle estimate off by 10.6 percentage points, on the low side, and the stated range covers the measured number.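

In this assay, the step for methoxy in place of methyl on an aromatic carbon is a number 5.1 percentage points higher from compound 1 to compound 4 (within the scatter), and it can be set beside the same change on the other core: the same change on two cores in this assay, a number 6.2 percentage points lower (within the scatter) from compound 3 to compound 2 and a number 5.1 percentage points higher (within the scatter) from compound 1 to compound 4, 11.3 percentage points apart, within the scatter of two such steps

On these two pairs, the change carries from one core to the other without a difference that the scatter can separate. This does not show that the two steps are equal, and two pairs at one test concentration say nothing about further cores.

The compounds shown leave open whether a different group on this aromatic carbon, such as an amine or a longer alkoxy chain, would give a step beyond the scatter on either core.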